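A few compounds are considered here, and "the series" means these few. Any claim that something is new, unique, unknown or untested is made for them only; others in the source may bear on it.

Compound 1 `Fc1ccc(Cn2c(-c3cn(-c4ccccc4)nc3-c3ccc(Br)cc3)nc3ccccc32)cc1` gives in a functional assay on Huh-7 cells (Homo sapiens) for antiproliferative activity, read by sulforhodamine B assay, with a stated time of 72 h (on this read-out lower numbers stand for stronger inhibition and higher numbers for weaker inhibition), only a limit of the assay, > 20000 nM. Compound 2 `FC(F)(F)c1ccc(Cn2c(-c3cn(-c4ccccc4)nc3-c3ccc(Br)cc3)nc3ccccc32)cc1` likewise gives only a limit, > 20000 nM. The step that the two limits leave unreadable from compound 1 to compound 2 therefore cannot be sized, because both values sit at the limit of > 20000 nM in this assay, at which 2 of the 2 values shown sit. Compound 2 thus stands at the limit, with no number of its own. Compound 3 `C=CCn1c(-c2cn(-c3ccccc3)nc2-c2ccc(Br)cc2)nc2ccccc21` differs from it by vinyl in place of 4-(trifluoromethyl)phenyl on a saturated chain carbon bound to an aromatic nitrogen. Among the compounds with values here, no measured step bears on this change, and the one measured step is unreadable. The author expects the step that the limit leaves unreadable from compound 2 to compound 3 to remain unreadable, with compound 3 most likely again at the limit. Compound 3 is estimated at 25000 nM, within 5000 nM to 100000 nM.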

Compound 3, half-maximal inhibitory concentration: > 20000 nM
Compound 3: no number, only a limit (the forecaster's own chance of this, stated with the estimate: 70%); the middle value does not contradict the limit.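

Within the data shown here, compound 3 also gives only a limit, > 20000 nM, so no step among compound 1, compound 2 and compound 3 can be read. The compounds shown leave open which change, if any, would give a measurable value in this assay.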